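Reversing the aminomethyl swap on the fluoroalkene arm

The source may hold more compounds than are shown below. What is called first, only, known or untested is meant among the compounds shown, and "the series" means these compounds.

Of the compounds shown here, two have been measured in a functional assay on CCRF-CEM cells for antagonist activity at C-X-C chemokine receptor type 4 (Homo sapiens), read by calcium flux, with stated times of 25 min and 90 s; a higher number here means a weaker inhibitor, a lower number a stronger inhibitor. Compound 1 `C/C(CN)=C(/F)CN(C[C@H]1Cc2ccccc2CN1)[C@H]1CCCc2cccnc21` gives 44 nM, while compound 2 `C/C(CN(C[C@H]1Cc2ccccc2CN1)[C@H]1CCCc2cccnc21)=C(/F)CN` gives 1800 nM, the highest of the two numbers; the step of a 41-fold higher number from compound 1 to compound 2 (1.61 log units; beyond the scatter) was large. Compound 3 `C/C(CN)=C(\F)CN(C[C@H]1Cc2ccccc2CN1)[C@H]1CCCc2cccnc21` carries the change (2-(aminomethyl)-1-fluoroprop-1-en-1-yl in place of 3-amino-2-fluoro-1-methylprop-1-en-1-yl on a saturated chain carbon bound to an amine nitrogen), which returns the arm to the arrangement found in compound 1, though with a different geometry about the double bond. Because the reverse change gave a 41-fold higher number from compound 1 to compound 2 (1.61 log units; beyond the scatter), a step of roughly a 12-fold lower number from compound 2 to compound 3 (1.08 log units; beyond the scatter) is expected, and compound 3 is estimated at 150 nM, within a range from 30 nM to 900 nM.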

Compound 3, half-maximal inhibitory concentration: 28 nM
Beside the measured number, compound 3's estimate is 5.4-fold (0.73 log units) above it; the whole stated range lies above it.
By their numbers in this assay, from the lowest: compounds 3 and 1 (each within the scatter of the next); then compound 2.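

Changing to the 2-(aminomethyl)-1-fluoroprop-1-en-1-yl arm restores the activity missing from compound 2, with a 64-fold lower number from compound 2 to compound 3 (1.81 log units; beyond the scatter) in this assay. The double-bond geometry of this arm shows no measurable effect, with a 1.6-fold lower number from compound 1 to compound 3 (0.20 log units; within the scatter), and this comparison isolates that single feature: the fact that compounds 1 and 3 differ only in the configuration as drawn. For these compounds, the arrangement of the arm matters far more than whether its double bond is drawn Z or E.

Still open, going by these compounds, is whether the other double-bond geometry would rescue compound 2's arm. On these data alone, it is also open whether a hydroxyl group or a longer chain in place of the aminomethyl group would keep this activity.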